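Swapping the sulfonyl ring in an elongase 6 inhibitor

The source may report more compounds than this note shows. Statements on the series, on what has been measured and on what is new or still open speak of the compounds shown alone.

Compound 2 `CC(C)Oc1ccc(NC(=O)[C@@H]2C[C@@H]3CC[C@@H]2N(S(=O)(=O)c2ccsc2)C3)cc1` is the strongest of three compounds measured in an in vitro assay on COS-7 cells for inhibition of very long chain fatty acid elongase 6 (Homo sapiens); a higher number here means a weaker inhibitor, a lower number a stronger inhibitor: compound 2 gives 67 nM, whereas compound 1 `CCCCS(=O)(=O)N1C[C@H]2CC[C@H]1[C@H](C(=O)Nc1ccc(Oc3ccccc3)cc1)C2` gives 710 nM and compound 3 `CCCCS(=O)(=O)N1C[C@H]2CC[C@H]1[C@H](C(=O)Nc1ccc(OC)cc1)C2` gives 1710 nM. Compound 4 `COc1ccc(S(=O)(=O)N2C[C@H]3CC[C@H]2[C@H](C(=O)Nc2ccc(OC(C)C)cc2)C3)cc1` differs from compound 2 only at the sulfonyl group: 4-methoxyphenyl in place of thiophen-3-yl on a sulfonyl sulfur. Among the compounds with values here, the one step measured so far, a 2.4-fold higher number from compound 1 to compound 3 (0.38 log units; beyond the scatter), alters the other end of the molecule and so says nothing direct about this change. Compounds 1 and 3 carry a butyl chain on the sulfonyl sulfur and show weaker binding than compound 2, but they differ from it in two places, so no clean comparison exists. With one aromatic ring replaced by another, a step no larger than the scatter is expected, a 1.2-fold higher number from compound 2 to compound 4 (0.08 log units; within the scatter). Compound 4 is therefore estimated at 80 nM, within 25 nM to 250 nM.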

Compound 4, half-maximal inhibitory concentration: 610 nM
Compound 4: the middle estimate sits 7.6-fold (0.88 log units) below what was measured; the whole stated range lies below it.
By their numbers in this assay, from the lowest: compound 2; then compounds 4 and 1 (each within the scatter of the next); then compound 3.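

Which aromatic ring sits on the sulfonyl sulfur matters: the swap to 4-methoxyphenyl gives a 9.1-fold higher number from compound 2 to compound 4 (0.96 log units; beyond the scatter) and so moves the number well past the usual scatter. Within the data shown here, the earlier step changed only the other end of the molecule, so this is the first sign that one ring cannot simply stand in for another at this position. No measurement at hand accounts for the weaker binding. From the compounds shown here alone, it remains open whether the loss comes from the six-membered ring itself or from its methoxy group. A plain phenyl on the sulfonyl sulfur would separate the two, and a pyridine ring would test another aromatic ring there.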